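A few compounds are considered here, and "the series" means these few. Any claim that something is new, unique, unknown or untested is made for them only; others in the source may bear on it.

Compound 1 `O=C(Nc1cccc(-n2cc(-c3ccncc3)c(-c3cc(O)cc(Cl)c3)n2)c1)Nc1ccc(Cl)c(C(F)(F)F)c1` gives 104% in a functional assay on SK-MEL-2 cells (Homo sapiens) for inhibition, read by sulforhodamine B assay, with a stated time of 48 h, tested at 1 uM (a lower number here means a stronger effect, a higher number a weaker effect of the compound at the concentration tested), the highest of the two numbers at hand. Among the measured compounds shown here, compound 2 `O=C(Nc1cccc(-n2cc(-c3ccncc3)c(-c3cc(O)cc(Cl)c3)n2)c1)Nc1ccc(Cl)c(Cl)c1` gives 56% in this assay, and the step of a number 48 percentage points lower from compound 1 to compound 2 (beyond the scatter) is the only measured change in the set. Compound 3 `COc1cc(Cl)cc(-c2nn(-c3cccc(NC(=O)Nc4ccc(Cl)c(C(F)(F)F)c4)c3)cc2-c2ccncc2)c1` differs from compound 1 in methyl in place of hydrogen on an oxygen on an aromatic ring. For the measured compounds named here, that measured step alters a different part of the structure, so no step bears on the hydroxy to methoxy change, and no direction can be read from it. For compound 3 the expected step is a number 6 percentage points lower from compound 1 to compound 3 (within the scatter), none beyond the scatter. Compound 3 is estimated at 98%, within 70% to 115%.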

Compound 3, a percentage reported as activity, at one concentration (the size of the read-out at that concentration, not a potency): 84%
Beside the measured number, compound 3's estimate is 14 percentage points above it, and the stated range covers the measured number.
By their numbers in this assay, from the lowest: compound 2; then compound 3; then compound 1.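

Hydroxy to methoxy on the 3-chloro-5-hydroxyphenyl ring is the first measured change at this oxygen, and in this assay it gives a number 20 percentage points lower from compound 1 to compound 3 (beyond the scatter). The position therefore responds to a methyl on the oxygen, and a free hydroxy is not required for the effect seen at this concentration. No measurement at hand accounts for this step.

Open, as far as these compounds go, is whether a longer chain on that oxygen, such as ethoxy, or an amine in place of the hydroxy, would shift the number. Also open, from the compounds shown here alone, is whether the hydroxy to methoxy step holds on the dichlorophenyl urea of compound 2.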